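Swapping chloro for fluoro on a fused-ring amide series

The compounds below may be only part of what the source reports. "The series", "measured", "known", "first", "only" and "open" are said of these compounds alone.

Measured compounds:
compound 1 `O=C(/C=C1\CCc2ccc(F)cc21)NCC1CC1`, 21%
compound 2 `CCNC(=O)/C=C1\CCc2ccc(F)cc21`, 63%
compound 3 `CNC(=O)/C=C1\CCc2ccc(Cl)cc21`, 25%

Compound 3 gives the second highest of the three numbers in a functional assay on the whole organism with Rattus norvegicus as the target, at a dose of 20 mg/kg by the oral route; a lower number here means less inhibition, a higher number more inhibition at the dose given (going by the name of the read-out). Its nearest neighbour is compound 1, whose value sits within the scatter of repeated measurements, so the two cannot be told apart; compound 2 stands well beyond the scatter above both.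

Compound 4 `CNC(=O)/C=C1\CCc2ccc(F)cc21` is the one not yet measured. It differs from compound 3 in a single place: fluoro in place of chloro on an aromatic carbon.

For the measured compounds named here, the only measured step, a number 42 percentage points higher from compound 1 to compound 2 (beyond the scatter), concerns the group on the amide nitrogen, not the halogen on the aromatic ring. Going by the values given here, no measured pair in this set differs only in the halogen, so nothing here speaks directly to the change from compound 3 to compound 4. Without such a comparison, the expectation for compound 4 is a step of a number 5 percentage points higher from compound 3 to compound 4 (within the scatter), that is, no change beyond the scatter. Compound 4 is therefore estimated at 30%, with a range from 10% to 55%.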

Compound 4, a percentage reported as inhibition, in the whole organism at one dose (the size of the read-out at that dose, not a potency): 38%
For compound 4 the middle estimate is 8 percentage points below the measured one, and the stated range covers the measured number.
By their numbers in this assay, from the lowest: compounds 1 and 3 (each within the scatter of the next); then compound 4; then compound 2.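

The halogen on the aromatic ring now matters on a measured basis in this assay, with a number 13 percentage points higher from compound 3 to compound 4 (beyond the scatter) for fluoro in place of chloro, so this ring carbon is not indifferent to the change. Compound 4 also gives a third point for the group on the amide nitrogen, with a number 25 percentage points lower from compound 2 to compound 4 (beyond the scatter) and a number 17 percentage points higher from compound 1 to compound 4 (beyond the scatter), and so among these fluoro compounds methyl falls between ethyl in compound 2 and cyclopropylmethyl in compound 1. Nothing available here explains either the halogen step or the order of the nitrogen groups.

From the compounds shown here alone, whether the same halogen swap gives a similar step with ethyl on the amide nitrogen stays open. What a methoxy group or a nitrile at this ring carbon would give, or a longer chain on the amide nitrogen, also remains an open question.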